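This account rests on a few compounds, and the source may have more. Where it says the series, first, only, none or still open, it means among the compounds named here.

Series notes on an assay on isolated protein for inhibition of Leucine-rich repeat serine/threonine-protein kinase 2 (Homo sapiens), read by TR-FRET and LanthaScreen, with stated times of 50 min and 30 min, in the presence of a further agent that is not named here; a higher number here means a weaker inhibitor, a lower number a stronger inhibitor. Compound 2 `Cc1nn(C)cc1Nc1nc(N)c2c(C#N)c(N3CCC[C@H]3C)n(C)c2n1` gives 38 nM. Compound 1 `Cc1nn(CC2(O)COC2)cc1Nc1nc(N)c2c(C#N)c(N3CCC[C@H]3C)n(C)c2n1`, which carries the 3-hydroxyoxetan-3-yl group on a saturated chain carbon bound to an aromatic nitrogen, gives 57 nM; compound 3 `C[C@@H]1CCCN1c1c(C#N)c2c(N)nccc2n1C`, whose core carries no pyrazolylamino arm at all, gives 34 nM. Among these three numbers compound 2 stands second highest, with compound 3 nearest and compound 1 furthest, both within the usual scatter. Among the compounds with values here, the single measured step, a 1.5-fold lower number from compound 1 to compound 2 (0.18 log units; within the scatter), touches only the substituent on the pyrazole and stays within the scatter.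

Compound 4 `C[C@@H]1CCCN1c1c(C#N)c2c(N)nc(N)nc2n1C` is not yet measured. It differs from compound 2 by hydrogen in place of 1,3-dimethyl-1H-pyrazol-4-yl on a nitrogen on an aromatic ring; seen one bond further out, (1,3-dimethyl-1H-pyrazol-4-yl)amino becomes amino. Within the data shown here, no measured step removes this group, so the step from compound 1 to compound 2 bears on it only loosely, as a hint that alterations on the pyrazole leave the number where it was. More telling is that compound 3, with no such arm, gives 34 nM against 38 nM for compound 2, two numbers within the scatter of each other. The expected step is therefore no larger than the scatter, with a slight lean to a higher number, and a 1.3-fold higher number from compound 2 to compound 4 (0.12 log units; within the scatter) is the estimated step. Compound 4 is estimated at 50 nM, with a range from 20 nM to 150 nM.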

Compound 4, half-maximal inhibitory concentration: 248 nM
For compound 4 the middle estimate is 5.0-fold (0.70 log units) below the measured one; measured number above the stated range.
By their numbers in this assay, from the lowest: compounds 3, 2 and 1 (each within the scatter of the next); then compound 4.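

In this assay, within the data shown here, replacing the 1,3-dimethyl-1H-pyrazol-4-yl group on this nitrogen with hydrogen, so that (1,3-dimethyl-1H-pyrazol-4-yl)amino becomes amino, gives the one step beyond the scatter (a 6.5-fold higher number from compound 2 to compound 4 (0.81 log units; beyond the scatter)). The earlier step (a 1.5-fold lower number from compound 1 to compound 2 (0.18 log units; within the scatter)) stayed within the scatter, but it altered only the substituent on the pyrazole and kept the ring on the nitrogen, so it could say nothing about losing the whole group. Taken together, the two steps show that, on this core, the number held across a change on the pyrazole but not when the group left the nitrogen altogether. Nothing at hand accounts for the size of this step.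

From the compounds shown here alone, it remains open whether a single methyl group on this nitrogen, a phenyl ring or a pyrazole without its methyl groups would keep the number close to that of compound 2 (38 nM). One step also cannot tell whether an amine, a carboxylic acid or a longer chain on the pyrazole would stay as close as the 3-hydroxyoxetan-3-yl group did.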